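A few compounds are considered here, and "the series" means these few. Any claim that something is new, unique, unknown or untested is made for them only; others in the source may bear on it.

Values in a functional assay on SMMC-7721 cells (Homo sapiens) for inhibition, read by MTT assay, with a stated time of 48 h; on this read-out higher numbers stand for weaker inhibition and lower numbers for stronger inhibition:
- compound 1 `Cc1ccc(NC(=O)Nc2cccc(-c3cccc4[nH]nc(N)c34)c2)cc1Cl`: 510 nM
- compound 2 `Nc1n[nH]c2cccc(-c3cccc(NC(=O)Nc4ccccc4F)c3)c12`: 2360 nM

Of the two numbers in this assay, compound 2 has the higher, at 2360 nM, and so shows the weaker inhibition. The next structure, compound 3 `Nc1n[nH]c2cccc(-c3cccc(NC(=O)Nc4cccc(C(F)(F)F)c4)c3)c12`, differs from compound 2 in one place: 3-(trifluoromethyl)phenyl in place of 2-fluorophenyl on an amide-type nitrogen. In words, 3-(trifluoromethyl)phenyl stands in place of 2-fluorophenyl on an amide-type nitrogen.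

Among the compounds with values here, only one measured step bears on this change: a 4.6-fold higher number from compound 1 to compound 2 (0.67 log units; beyond the scatter). It is modest but beyond the scatter, and it involves the same place and the same leaving group. It shows that 2-fluorophenyl is not the better of the two groups tested so far, but it says nothing directly about 3-(trifluoromethyl)phenyl. A lower number is therefore expected in this assay, with some caution about its size, and a step smaller than the measured one seems most likely. The expected step is a 2.4-fold lower number from compound 2 to compound 3 (0.37 log units; beyond the scatter). For compound 3 the estimated value is 1000 nM, with an expected range from 350 nM to 2800 nM.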

Compound 3, half-maximal inhibitory concentration: 1410 nM
For compound 3 the middle estimate is 1.4-fold (0.15 log units) below the measured one; the measured number falls inside the stated range.
By their numbers in this assay, from the lowest: compound 1; then compounds 3 and 2 (each within the scatter of the next).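

In this assay, placing 3-(trifluoromethyl)phenyl in place of 2-fluorophenyl on the amide-type nitrogen gives a 1.7-fold lower number from compound 2 to compound 3 (0.22 log units; within the scatter), so this read-out does not separate these two groups, even though the entering group has more heavy atoms and more fluorine. Replacing 3-chloro-4-methylphenyl with the same group gives a 2.8-fold higher number from compound 1 to compound 3 (0.44 log units; beyond the scatter), so compound 1 now holds the lowest number of the three, with its steps to both other compounds beyond the scatter. No measurement at hand accounts for either step.

The compounds shown leave open whether the chlorine or the methyl of compound 1 carries its advantage, as neither substituent appears alone on the phenyl ring at this place. Also open, going by these compounds, is how unsubstituted phenyl, or a non-aromatic group such as cyclohexyl or a carbon chain ending in an amine, would read on the same nitrogen in this assay.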